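This account rests on a few compounds, and the source may have more. Where it says the series, first, only, none or still open, it means among the compounds named here.

Compound 1 `CCOc1ccccc1-c1ccc(-c2nc3cnccc3c(NC(C)C(=O)O)c2C#N)cc1` carries a 1-carboxyethyl group on a ring nitrogen, and in a physicochemical assay for lipophilicity, read by HPLC, at pH 7.5 (a higher number here means a more lipophilic compound, a lower number a more polar compound), compound 1 gives 2.1. Among the compounds with values here, that is the lowest of the three numbers measured so far. Compound 2 `CC[C@H](Nc1c(C#N)c(-c2ccc(Br)cc2)nc2cnccc12)C(N)=O` gives 2.3 in this assay, which lies within the usual scatter of the value for compound 1, so the two cannot be told apart. Compound 3 `CC[C@@H](Nc1c(C#N)c(-c2ccc(-c3ccccc3C(F)(F)F)cc2)nc2cnccc12)C(N)=O` gives 3.1, a clearly higher number. Compound 4 `CCOc1ccccc1-c1ccc(-c2nc3cnccc3c(N[C@@H]3CCOC3=O)c2C#N)cc1` has not yet been measured. It differs from compound 1 in one place: 2-oxooxolan-3-yl in place of 1-carboxyethyl on a nitrogen on an aromatic ring. Within the data shown here, with no measured pair showing this exact exchange, the expectation rests on the structures alone, and a sizeable rise from compound 1 to compound 4 is expected, a number 1.10 log units higher from compound 1 to compound 4 (beyond the scatter). Compound 4 is therefore estimated at 3.2, between 2.5 and 3.9.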

Compound 4, distribution coefficient: 2.7
Compound 4: the middle estimate sits 0.50 log units above what was measured; measured number inside the range.
By their numbers in this assay, from the lowest: compounds 1 and 2 (each within the scatter of the next); then compound 4; then compound 3.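

In this assay, exchanging 1-carboxyethyl for 2-oxooxolan-3-yl on a nitrogen on an aromatic ring gives a number 0.60 log units higher from compound 1 to compound 4 (beyond the scatter) and is the only single-place step shown at this position. With the rest of compound 1 unchanged, the reading therefore responds to the group held on this nitrogen. No measurement here accounts for the size of the step.

As far as these compounds go, it remains open whether the step goes with the ring of 2-oxooxolan-3-yl or with the hydrogen-bond donor of 1-carboxyethyl, which 2-oxooxolan-3-yl lacks. An open-chain methyl ester on the same nitrogen would help to separate the two.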